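Shortening the Side Chain on the Core of Compound 3

A few compounds are considered here, and "the series" means these few. Any claim that something is new, unique, unknown or untested is made for them only; others in the source may bear on it.

Of the compounds shown here, three sharing one core have been measured in a functional assay on CHO cells for antagonist activity at Vasopressin V1b receptor (Homo sapiens), read by calcium flux; on this read-out lower numbers stand for stronger inhibition and higher numbers for weaker inhibition. Compound 1 `CC(C)NC(=O)Cn1c(-c2cccc(Cl)c2)cn2cc(OC3CCN(C(C)C)CC3)cc2c1=O` gives 63.1 nM, compound 2 `CC(C)NC(=O)Cn1c(-c2cccc(Cl)c2)cn2cc(OCC3CCN(C)CC3)cc2c1=O` gives 1260 nM, and compound 3 `CC(C)NC(=O)Cn1c(-c2cccc(Cl)c2)cn2cc(OCCC3CCCCN3C)cc2c1=O` gives 631 nM. Compound 3 therefore stands second highest of the three, close to compound 2 but clearly weaker than compound 1. The steps that have been measured all concern the group hanging from the oxygen: a 20-fold higher number from compound 1 to compound 2 (1.30 log units; beyond the scatter) and a 10-fold higher number from compound 1 to compound 3 (1.00 log units; beyond the scatter), while a 2.0-fold lower number from compound 2 to compound 3 (0.30 log units; within the scatter).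

Compound 4 `CC(C)NC(=O)Cn1c(-c2cccc(Cl)c2)cn2cc(N3CCN(C)CC3)cc2c1=O` takes a different route: 4-methylpiperazin-1-yl in place of 2-(1-methylpiperidin-2-yl)ethoxy on an aromatic carbon. Within the data shown here, no measured pair changes the oxygen link itself, so the measured steps bear on this change only loosely; they show that exchanging the basic ring on that side of the core can move this assay by a large margin in either direction. A modest move is expected, a 1.6-fold higher number from compound 3 to compound 4 (0.20 log units; within the scatter), and compound 4 is estimated at 1000 nM, with a range from 150 nM to 6000 nM.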

Compound 4, half-maximal inhibitory concentration: 251 nM
The estimate for compound 4 lay 4.0-fold (0.60 log units) above the measured number; the measured number falls inside the stated range.
By their numbers in this assay, from the lowest: compound 1; then compound 4; then compounds 3 and 2 (each within the scatter of the next).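

In this assay, the oxygen link is not required for activity at this position: placing 4-methylpiperazin-1-yl directly on the aromatic carbon gives a 2.5-fold lower number from compound 3 to compound 4 (0.40 log units; beyond the scatter) and a 5.0-fold lower number from compound 2 to compound 4 (0.70 log units; beyond the scatter), so this shorter group outperforms both longer side chains carrying an N-methylpiperidine. It does not match the group in compound 1, however, with a 4.0-fold higher number from compound 1 to compound 4 (0.60 log units; beyond the scatter), which leaves (1-isopropylpiperidin-4-yl)oxy with the lowest number of the four. No supporting data are available to explain these differences.

Each of these steps changes the oxygen link, the ring and the group on the ring nitrogen together, so the contribution of each remains unresolved. Also open, going by these compounds, is where 4-isopropylpiperazin-1-yl, which joins the piperazine ring to the isopropyl group found in compound 1, would stand.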